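A few compounds are considered here, and "the series" means these few. Any claim that something is new, unique, unknown or untested is made for them only; others in the source may bear on it.

- compound 1 `Cc1cc(/C=C/C#N)cc(C)c1Oc1cc(Nc2ccc(C#N)cc2)c(N)cc1C(N)=O` in a physicochemical assay for solubility, with a stated time of 4 h, at pH 2.0; a higher number here means a more soluble compound, a lower number a less soluble compound: 2.09 ug/mL
- compound 2 `Cc1cc(CCC#N)cc(C)c1Oc1cc(Nc2ccc(C#N)cc2)c(N)cc1C(F)(F)F` in this assay: 0.33 ug/mL

Going by the values given here, of the two numbers so far, compound 1 holds the higher, at 2.09 ug/mL, and compound 2 holds the lower, at 0.33 ug/mL, a gap beyond the scatter. These two compounds differ in more than one place, so their gap does not isolate any single change.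

Next in line is compound 3 `Cc1cc(/C=C/C#N)cc(C)c1Oc1cc(Nc2ccc(C#N)cc2)c(N)cc1CO`, with hydroxymethyl in place of carbamoyl on an aromatic carbon. Among the compounds with values here, no measured step covers this exchange. In this assay, the expected outcome is no step beyond the scatter, with a slight lean downward. The estimated 1.4-fold lower number from compound 1 to compound 3 (0.14 log units; within the scatter) is therefore small. For compound 3 the expected value is 1.5 ug/mL, within an estimated range of 0.5 ug/mL to 4.5 ug/mL.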

Compound 3, solubility: 20.9 ug/mL
Compound 3: the middle estimate sits 14-fold (1.14 log units) below what was measured; measured number outside the range, above it.
By their numbers in this assay, from the lowest: compound 2; then compound 1; then compound 3.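

In this assay, going by these compounds alone, the exchange of carbamoyl for hydroxymethyl on this aromatic carbon, para to a (4-cyanophenyl)amino group, gives a 10-fold higher number from compound 1 to compound 3 (1.00 log units; beyond the scatter) and is the first step that isolates a single change. This position is therefore not neutral for the read-out on the core of compound 1, even though the counted hydrogen-bond donors and acceptors are the same in the two groups. No available measurement accounts for the size of this step. Still open, from the compounds shown here alone, is how an aminomethyl group, a methoxymethyl group or a carboxylic acid on this carbon would read in this assay against hydroxymethyl. Also open, going by these compounds, is whether hydroxymethyl gives a step of like size when the rest of the molecule carries the saturated side chain of compound 2.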